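Pyrazole for fluoropyridine on the thiazole acetic acid series

The compounds below may be only part of what the source reports. "The series", "measured", "known", "first", "only" and "open" are said of these compounds alone.

Measured so far:
compound 1 `Cc1nc(-c2ccc(Cl)cc2)c(CC(=O)O)s1` 50%
compound 2 `O=C(O)Cc1sc(C(c2ccc(F)cc2)c2ccc(F)cc2)nc1-c1ccnc(F)c1` 80%
compound 3 `O=C(O)Cc1sc(C(c2ccccc2)c2ccc(Cl)cc2)nc1-c1ccc(Cl)cc1` 80%

In an in vitro functional assay on HEK285-7 cells for antagonist activity at prostaglandin D2 receptor 2 (Homo sapiens), read by BRET and beta-arrestin recruitment (a higher number here means a larger maximal response, a lower number a smaller maximal response), compound 2 gives 80%. Compound 3 stands level with it at the digits shown, within the scatter, so the two share the highest number of the three. Compound 1 gives 50%. That puts compound 1 a good deal lower than compound 2, and the gap between them is wider than the usual scatter. Compounds 2 and 3 carry different aryl groups at the position in question and still read the same, which is the only hint available on how much that position matters.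

Compound 4 `O=C(O)Cc1sc(C(c2ccc(F)cc2)c2ccc(F)cc2)nc1-c1cn[nH]c1` is not yet measured. It differs from compound 2 in one place: 1H-pyrazol-4-yl in place of 2-fluoropyridin-4-yl on an aromatic carbon. A six-membered aromatic ring with 1 hetero atom gives way to a five-membered aromatic ring with 2 hetero atoms, bringing 1 hydrogen-bond donor where there was none.

For the measured compounds named here, no step between measured compounds is known for this change. Given that compound 2 at 80% and compound 3 at 80% agree despite different groups here, the expected step of a number 6 percentage points lower from compound 2 to compound 4 (within the scatter) is small, at most a modest drop, not clearly beyond the scatter. Compound 4 is estimated at 74%, between 55% and 90%.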

Compound 4, largest response reached (reported as efficacy), in percent of the reference or control that the assay uses: 80%
Compound 4: middle estimate off by 6 percentage points, on the low side; low and high end bracket the measured number.
By their numbers in this assay, from the lowest: compound 1; then compounds 2, 3 and 4 (each within the scatter of the next).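

In this assay, 1H-pyrazol-4-yl in place of 2-fluoropyridin-4-yl on the aromatic carbon next to the ring nitrogen gives no change at the digits printed from compound 2 to compound 4 (within the scatter). For the compounds shown here, this is the first step at this position with the rest of the structure held constant, and it shows that the maximal response stays put when a five-membered aromatic ring with 2 hetero atoms replaces a six-membered one with 1 hetero atom, the fluorine is lost and a hydrogen-bond donor enters. No supporting data bear on why the read-out holds across this change.

Open, from the compounds shown here alone, is whether the hydrogen-bond donor of the pyrazole can be capped, as in 1-methylpyrazol-4-yl, without a step beyond the scatter. Also open, going by these compounds, is whether the position accepts a non-aromatic group such as morpholine or a basic amine.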